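A few compounds are considered here, and "the series" means these few. Any claim that something is new, unique, unknown or untested is made for them only; others in the source may bear on it.

Working notes on the series. Among the measured compounds shown here, compound 2 `C[C@H](NCCSCCC(N)C(=O)O)C(=O)O` heads the two numbers measured so far in an assay for inhibition of betaine--homocysteine S-methyltransferase 1 (Homo sapiens), tested at 20 uM (a higher number here means more inhibition at the concentration tested (going by the name of the read-out), a lower number less inhibition), where compound 2 gives 19.8%; its nearest neighbour is compound 1 `C[C@@H](NCCSCCC(N)C(=O)O)C(=O)O`, which in this assay gives 15.5%. For the measured compounds named here, the only step measured is a number 4.3 percentage points higher from compound 1 to compound 2 (within the scatter), a change that rests solely on (the fact that one of compounds 1 and 2 is drawn with a defined configuration and the other without, at the place where they differ); it says nothing about replacing one chain with another.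

Compound 3 `NC(CCSCCNCCC(=O)O)C(=O)O` is the next member, differing from compound 2 by 2-carboxyethyl in place of 1-carboxyethyl on an amine nitrogen. Going by the values given here, no measured step rearranges the chain on an amine nitrogen whose other neighbours are a saturated chain carbon, so no precedent for the direction or size of the move exists. Among the compounds with values here, with the one measured step lying within the scatter and no bearing on this change, no step beyond the scatter is expected in this assay.

The expected step from compound 2 to compound 3 in this assay is a number 1.8 percentage points lower from compound 2 to compound 3 (within the scatter). Compound 3 is therefore estimated at 18%, with a range from 5% to 32%.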

Compound 3, a percentage reported as inhibition, at one concentration (the size of the read-out at that concentration, not a potency): 0%
Compound 3: middle estimate off by 18 percentage points, on the high side; the measured number lies below the stated range.
By their numbers in this assay, from the lowest: compound 3; then compounds 1 and 2 (each within the scatter of the next).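

Moving from 1-carboxyethyl to 2-carboxyethyl on an amine nitrogen gives the first steps in the series beyond the scatter in this assay: a number 19.8 percentage points lower from compound 2 to compound 3 (beyond the scatter), and a number 15.5 percentage points lower from compound 1 to compound 3 (beyond the scatter). The two chains have the same atoms, so this position responds to how the chain is joined, whereas the configuration of the 1-carboxyethyl group gave only a step within the scatter. Nothing on record bears on why this rearrangement lowers the read-out.

The compounds shown leave open whether carboxymethyl or a longer chain such as 3-carboxypropyl on this amine nitrogen would give a number nearer that of compound 2 or of compound 3. They also leave open how an amide in place of the carboxylic acid of the 1-carboxyethyl group would read in this assay.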